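Compound 3: One Stereocentre Drawn the Other Way

The compounds below may be only part of what the source reports. "The series", "measured", "known", "first", "only" and "open" are said of these compounds alone.

Compound 1 `CC(C)c1n[nH]c2c(NCc3ccccc3N)nc(NC[C@@H](C)O)nc12`: 15500 nM
Compound 2 `CC[C@@H](CO)Nc1nc(NCc2ccccc2N)c2[nH]nc(C(C)C)c2n1`: 22300 nM

Both values come from a functional assay on K562 cells (Homo sapiens) for inhibition, read by fluorescence, with a stated time of 72 h (on this read-out lower numbers stand for stronger inhibition of growth and higher numbers for weaker inhibition of growth), and compound 2 stands within the scatter of compound 1. Compound 3 `CC[C@H](CO)Nc1nc(NCc2ccccc2N)c2[nH]nc(C(C)C)c2n1` differs from compound 2 in one respect: the two compounds have the same atoms and bonds and differ only in configuration as drawn: 1 of 1 stereo elements differ; a stereocentre at a saturated chain carbon is drawn S in compound 2 and R in compound 3. Within the data shown here, the only measured step, a 1.4-fold higher number from compound 1 to compound 2 (0.16 log units; within the scatter), came with 1-(hydroxymethyl)propyl in place of 2-hydroxypropyl. Among the measured compounds shown here, no measured pair tests configuration at this stereocentre, so no step beyond the scatter is expected in this assay. The expected step is a 1.1-fold lower number from compound 2 to compound 3 (0.05 log units; within the scatter). The estimate for compound 3 is 20000 nM, with an expected range from 8000 nM to 45000 nM.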

Compound 3, concentration for 50% growth inhibition: 9200 nM
Estimate against measurement, compound 3: 2.2-fold (0.34 log units) above, within the range that was stated.
By their numbers in this assay, from the lowest: compounds 3, 1 and 2 (each within the scatter of the next, the first and the last beyond it).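

In this assay, among these compounds, the configuration at this saturated chain carbon matters, though modestly: the change drawn here gives a 2.4-fold lower number from compound 2 to compound 3 (0.38 log units; beyond the scatter) and is the first step beyond the scatter. The step can be placed on this stereocentre alone because nothing else separates the pair: the fact that compounds 2 and 3 differ only in the configuration as drawn. With the R drawing, 1-(hydroxymethyl)propyl in place of 2-hydroxypropyl gives a 1.7-fold lower number from compound 1 to compound 3 (0.23 log units; within the scatter) and stays within the scatter. The compounds shown leave open whether a longer chain on this carbon, or an amine in place of the hydroxyl, would keep the gap between the two configurations.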